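Phenyl in Place of Chloro: Estimating Compound 4

This account rests on a few compounds, and the source may have more. Where it says the series, first, only, none or still open, it means among the compounds named here.

Measured compounds:
compound 1, `CC(=O)c1ccc(Nc2ccnc(SCC(=O)c3ccc(Br)cc3)n2)cc1`, 29%
compound 2, `CC(=O)c1cccc(Nc2ccnc(SCC(=O)c3ccc(-c4ccccc4)cc3)n2)c1`, 38%
compound 3, `CC(=O)c1ccc(Nc2ccnc(SCC(=O)c3ccc(Cl)cc3)n2)cc1`, 29%

In a functional assay on NCI-H522 cells (Homo sapiens) for inhibition, read by sulforhodamine B assay, with a stated time of 48 h, tested at 10 uM (on this read-out higher numbers stand for more inhibition of growth at the one concentration tested and lower numbers for less inhibition of growth), compound 3 stands level with compound 1, and compound 2 reads a number that differs from it only by an amount within the usual scatter. The one step that joins two of these compounds, no change at the digits printed from compound 1 to compound 3 (within the scatter), swaps one halogen for another and leaves the read-out unchanged.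

Compound 4, `CC(=O)c1ccc(Nc2ccnc(SCC(=O)c3ccc(-c4ccccc4)cc3)n2)cc1`, has not been measured. It differs from compound 3 in a single place: phenyl in place of chloro on an aromatic carbon. Going by the values given here, no measured step makes this exact change on the same core; compound 2 also carries a phenyl, but it differs from compound 3 in more than one place, so its value shows only that a phenyl-bearing compound can reach the level it gives. The halogen swap gave no change, and nothing in the measured numbers points to a step beyond the scatter.

Compound 4 is therefore expected to give 35%, in a range from 20% to 52%. The estimated step is a number 6 percentage points higher from compound 3 to compound 4 (within the scatter).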

Compound 4, percent growth inhibition at one concentration: 22%
Beside the measured number, compound 4's estimate is 13 percentage points above it, within the range that was stated.
By their numbers in this assay, from the lowest: compounds 4, 1, 3 and 2 (each within the scatter of the next, the first and the last beyond it).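

In this assay phenyl in place of chloro on this aromatic carbon gives a number 7 percentage points lower from compound 3 to compound 4 (within the scatter) and phenyl in place of bromo gives a number 7 percentage points lower from compound 1 to compound 4 (within the scatter) so this assay does not separate the larger ring from either halogen at this position. With the phenyl held fixed, 4-acetylphenyl in place of 3-acetylphenyl on the nitrogen gives a number 16 percentage points lower from compound 2 to compound 4 (beyond the scatter) and this modest step is the only one among these compounds that lies beyond the scatter. The clearest difference here therefore goes with where the acetyl group sits on its ring, not with the group at the far end of the molecule.

From the compounds shown here alone, it stays open whether the acetyl shift gives a similar step with chloro or bromo in place of the phenyl, and what an amine or a carboxylic acid would give at this position. No supporting data are available to explain these numbers.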